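Demethylation of one aryl methoxy in a dihydrobenzofuran series

This account rests on a few compounds, and the source may have more. Where it says the series, first, only, none or still open, it means among the compounds named here.

Measured compounds:
compound 1, `COc1ccc(-c2c(C)oc3cc(OC)c(O)cc23)cc1O`, "not active" (no number reported)
compound 2, `COc1ccc([C@H]2Oc3cc(OC)c(OC)cc3[C@@H]2C)cc1O`, > 19.4 ug/mL
compound 3, `COc1ccc(-c2oc3cc(OC)c(O)cc3c2C)cc1O`, "not active" (no number reported)

Of the compounds shown here, three have been tested in a functional assay on MCF7 cells (Homo sapiens) for cytotoxicity, read by MTT assay; a lower number here means a stronger inhibitor, a higher number a weaker inhibitor. Compound 1 is reported as "not active" (no number reported), and compound 3 likewise as "not active" (no number reported), neither with a number. For compound 2 the result is a limit of the assay, > 19.4 ug/mL, so its standing among the numbers shown is simply that it sits at the limit of > 19.4 ug/mL in this assay, at which 1 of the 3 values shown sits, with no single value to compare against the other two entries. Within the data shown here, no pair of measured compounds differs in one place, so no measured step is available.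

Compound 4, `COc1ccc([C@H]2Oc3cc(OC)c(O)cc3[C@@H]2C)cc1O`, has not yet been measured in this assay. It differs from compound 2 by hydrogen in place of methyl on an oxygen on an aromatic ring. With compound 2 at the limit and the two further entries without numbers, the step from compound 2 to compound 4 is expected to be none beyond the scatter, a step that the limit leaves unreadable from compound 2 to compound 4, and the estimate for compound 4 is 30 ug/mL, within 12 ug/mL to 100 ug/mL, most probably reported again as a limit.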

Compound 4, half-maximal inhibitory concentration: 7.7 ug/mL
The estimate for compound 4 lay 3.9-fold (0.59 log units) above the measured number; the whole stated range lies above it.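

In this assay, among these compounds, replacing methyl with hydrogen on an oxygen on an aromatic ring, the change from methoxy to hydroxy, gives an at least 2.5-fold lower number from compound 2 to compound 4 (0.40 log units; beyond the scatter), the first step in this set that can be read. Among the compounds shown here, compound 4 is also the only compound here with a single number, so this one change is enough to move the series from a limit to a measurable value. The value for compound 2 is a limit, so the step gives only a minimum and its full size remains unknown: the limit of > 19.4 ug/mL in this assay, at which 1 of the 4 values shown sits.

From the compounds shown here alone, whether an ethoxy group, an amine or a carboxylic acid on this position would match, exceed or lose the gain seen with hydroxy remains open. Compound 1 and compound 3 carry no number and differ from compound 4 in more than one place, so they cannot show how the rest of the core contributes.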